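Working notes: from compound 2 to compound 3

The source may hold more compounds than are shown below. What is called first, only, known or untested is meant among the compounds shown, and "the series" means these compounds.

Measured so far in an in vitro ADME assay on microsomes from liver (Mus musculus) for pharmacokinetics, read by LC-MS, with a stated time of 10 min, tested at 1 uM (on this read-out higher numbers stand for fast clearance and lower numbers for slow clearance), as clearance:
compound 1 `COc1ccc(NC(=O)[C@H]2CN(C)C[C@@H]2c2ccc(/C=C/C(=O)Nc3ccccc3N)cc2)cc1`: 54 mL/min/kg
compound 2 `CN1C[C@H](C(=O)Nc2ccc(F)cc2F)[C@@H](c2ccc(/C=C/C(=O)Nc3ccccc3N)cc2)C1`: 27 mL/min/kg

In this assay, within the data shown here, compound 2 stands within the scatter of compound 1, the only other measured compound, as a 2.0-fold lower number from compound 1 to compound 2 (0.30 log units; within the scatter) shows. The change to compound 3 `CN1C[C@H](C(=O)Nc2ccccn2)[C@@H](c2ccc(/C=C/C(=O)Nc3ccccc3N)cc2)C1` is pyridin-2-yl in place of 2,4-difluorophenyl on an amide-type nitrogen and amounts to pyridin-2-yl in place of 2,4-difluorophenyl on an amide-type nitrogen. Among the measured compounds shown here, one measured step bears on it, since it falls on an amide-type nitrogen too: a 2.0-fold lower number from compound 1 to compound 2 (0.30 log units; within the scatter) stays within the scatter, with 2,4-difluorophenyl in place of 4-methoxyphenyl. This single step is thin evidence. For the measured compounds named here, no measured compound carries pyridin-2-yl, so the data favour no direction, and no step beyond the scatter is expected. The estimated step is a 1.1-fold higher number from compound 2 to compound 3 (0.05 log units; within the scatter) and carries no weight as a trend. Compound 3 is expected at 30 mL/min/kg within an estimated range from 13 mL/min/kg to 65 mL/min/kg as the working figure.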

Compound 3, clearance: 40 mL/min/kg
For compound 3 the middle estimate is 1.3-fold (0.12 log units) below the measured one, and the stated range covers the measured number.
By their numbers in this assay, from the lowest: compounds 2, 3 and 1 (each within the scatter of the next).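

On the amide-type nitrogen, this assay now covers a first ring with a hetero atom: pyridin-2-yl in place of 2,4-difluorophenyl gives a 1.5-fold higher number from compound 2 to compound 3 (0.17 log units; within the scatter) and pyridin-2-yl in place of 4-methoxyphenyl gives a 1.4-fold lower number from compound 1 to compound 3 (0.13 log units; within the scatter) as its two steps. With compound 1, compound 2 and compound 3, all three groups at this place stand within the scatter of one another, so a ring of carbon only and a ring with one hetero atom are not told apart by this read-out of clearance. Nothing at hand gives a reason for where these three numbers fall.

The compounds shown leave open whether any group on this amide-type nitrogen gives a step beyond the scatter, for example a carboxylic acid, a longer alkyl chain or a saturated ring carrying an amine. They also leave open whether pyridin-3-yl or pyridin-4-yl would stand with pyridin-2-yl, and whether a larger step could be reached at this place at all with the rest of the shared core unchanged.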